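This account rests on a few compounds, and the source may have more. Where it says the series, first, only, none or still open, it means among the compounds named here.

Compound 1 `COc1cccc(C(=O)N(C)/N=C/c2ccc(OC)c(OC)c2)c1` is one of three hydrazones measured in a functional assay on the whole organism (strain A/J) for inhibition, with Mus musculus as the target, with stated times of 1 h and 18 h, at a dose of 100 umol/kg by the oral route (a lower number here means less inhibition, a higher number more inhibition at the dose given (going by the name of the read-out)), where compound 1 gives 69%. Compound 2 `COc1ccc(/C=N/N(C)c2ncnc3ccccc23)cc1OC`, which carries the shared hydrazone arm on a different core, gives 66% in this assay, and compound 3 `COc1ccc(/C=N/N(C)C(=O)c2ccc(OC)c(OC)c2)cc1OC` gives 79%. Compound 1 thus sits between the other two numbers, and its gap to each of them is within the usual scatter of repeated measurements, so the three compounds cannot be told apart on these data.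

For the measured compounds named here, the only single-point step among the measured compounds runs from compound 1 to compound 3: a number 10 percentage points higher from compound 1 to compound 3 (within the scatter).

Compound 4 `COc1ccc(/C=N/N(C)C(=O)c2ccccc2)cc1OC` differs from compound 1 by hydrogen in place of methoxy on an aromatic carbon. This is the same kind of change as the step from compound 1 to compound 3, taken in the opposite direction on the same aromatic ring of the benzoyl part. Because that step was a number 10 percentage points higher from compound 1 to compound 3 (within the scatter), the step to compound 4 is expected to be no larger than the scatter, if anything slightly downward: a number 7 percentage points lower from compound 1 to compound 4 (within the scatter). Compound 4 is therefore estimated at 62%, within a range from 45% to 78%.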

Compound 4, a percentage reported as inhibition, in the whole organism at one dose (the size of the read-out at that dose, not a potency): 51%
Beside the measured number, compound 4's estimate is 11 percentage points above it; the measured number falls inside the stated range.
By their numbers in this assay, from the lowest: compound 4; then compounds 2, 1 and 3 (each within the scatter of the next, the first and the last beyond it).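

In this assay, replacing 3-methoxyphenyl with phenyl gives a number 18 percentage points lower from compound 1 to compound 4 (beyond the scatter), and this is the first step among these compounds to lie beyond the scatter. For the compounds shown here, the methoxy meta to a large group therefore counts at this dose: taking it away shifts the read-out by more than repeat measurements would, whereas the only earlier step, a number 10 percentage points higher from compound 1 to compound 3 (within the scatter), a change that adds a methoxy rather than removes one, could not be told from scatter. Nothing available accounts for the size of this drop or says what lies behind it.

The compounds shown offer only methoxy and hydrogen at this carbon, so they leave open whether the oxygen, the methyl or the whole group carries the difference, and how a hydroxyl group, a chlorine atom or an amine would read there. As far as these compounds go, each number also comes from a single dose, so it remains open whether this step would hold at other doses or reflects a change in potency.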